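Aryl swap on the core of compound 1: working notes

A few compounds are considered here, and "the series" means these few. Any claim that something is new, unique, unknown or untested is made for them only; others in the source may bear on it.

The series is followed in a functional assay on CWR22R cells (Homo sapiens) for antiproliferative activity, read by CCK-8 assay, with a stated time of 6 days; a lower number here means a stronger inhibitor, a higher number a weaker inhibitor. Compound 1 `N#Cc1ccc(N2CCc3cc(-c4cnc5ccccc5c4)ccc3C2)cc1C(F)(F)F` gives 25900 nM in this assay, the highest of the two numbers in hand. Compound 3 `Cn1nccc1-c1cccc2c1CCCN2c1ccc(C#N)c(C(F)(F)F)c1` gives 10400 nM in this assay; the gap from compound 1 to compound 3 lies beyond the usual scatter, and the two share only the nitrile-bearing aryl on the ring nitrogen, so no single-point comparison can be drawn between them. Compound 2 `CCN(c1ccc(C#N)c(Cl)c1)c1cc(-c2ccccc2)ccc1C` returns only a limit in this assay, > 30000 nM, and no number is known for it. One of the three values therefore sits at the limit of > 30000 nM in this assay, at which 1 of the 3 values shown sits. Going by the values given here, no step between two measured compounds that differ in one place is available, so the expectation below rests on the weak activity of the whole set.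

Compound 4 `N#Cc1ccc(N2CCc3cc(-c4ccncc4)ccc3C2)cc1C(F)(F)F` differs from compound 1 in one place: pyridin-4-yl in place of quinolin-3-yl on an aromatic carbon. Both groups keep one hydrogen-bond acceptor and no donor, so the change is mainly the loss of the second ring. With every measured number already weak, the step from compound 1 to compound 4 is expected to be small, leaning toward a weaker inhibitor, as a 1.2-fold higher number from compound 1 to compound 4 (0.06 log units; within the scatter). Compound 4 is therefore estimated at 30000 nM in this assay, with a range from 11000 nM to 65000 nM, and a real chance that only a limit is reported.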

Compound 4, half-maximal inhibitory concentration: 6940 nM
Compound 4: the middle estimate sits 4.3-fold (0.64 log units) above what was measured, outside the stated range (below it).
By their numbers in this assay, from the lowest: compounds 4 and 3 (each within the scatter of the next); then compound 1. At a limit, above all of these: compound 2.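

Pyridin-4-yl in place of quinolin-3-yl on this aromatic carbon gives the first readable step in the series: in this assay there is a 3.7-fold lower number from compound 1 to compound 4 (0.57 log units; beyond the scatter), so this position responds to the group it carries. The group that leaves has one more aromatic ring, of carbon only, and more heavy atoms than the group that enters, while the counts of hydrogen-bond donors and acceptors stay the same, so in this one pair the lower number comes with the smaller group and with no change in those counts. Nothing measured here bears on why the smaller group gives the lower number.

One step cannot show whether the trend continues with other groups at this carbon, or whether the ring nitrogen matters to it. Going by these compounds, how a pyridin-3-yl or pyrimidin-5-yl group, or a pyridine ring carrying an amine, would read on the core of compound 1 stays open, and so does whether any such group can bring the number well below that of compound 4.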